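A Cyanophenyl in Place of the Furan on the Shared Core

The source may report more compounds than this note shows. Statements on the series, on what has been measured and on what is new or still open speak of the compounds shown alone.

Measured in an assay on CHO-K1 cells for antagonist activity at adenosine receptor A1 (Homo sapiens), read by a beta-galactosidase reporter, with stated times of 15 min and 6 h; a higher number here means a weaker inhibitor, a lower number a stronger inhibitor:
compound 1 `CCc1ccc(-c2nc(N)c3cc(CN4[C@H](C)CCC[C@@H]4C)sc3n2)o1` — 190 nM
compound 2 `Nc1nc(-c2ccc(Cl)o2)nc2sc(CN3CCC(F)CC3)cc12` — 1080 nM
compound 3 `Nc1nc(-c2cccs2)nc2sc(CN3CCCC3)cc12` — > 10000 nM

Compound 1 holds the lowest of the two numbers shown in this assay; compound 2 sits higher by a gap beyond the scatter. The value of compound 3 is a limit of the assay, not a number, as told in the limit of > 10000 nM in this assay, at which 1 of the 3 values shown sits. Compound 4 `C[C@@H]1CCC[C@H](C)N1Cc1cc2c(N)nc(-c3cccc(C#N)c3)nc2s1` differs from compound 1 in one place: 3-cyanophenyl in place of 5-ethylfuran-2-yl on an aromatic carbon. Going by the values given here, no two measured compounds differ in a single place, so no measured step guides the size of this change, and the aryl variation across compounds 1 to 3 gives only loose bearings. A modest rise in this assay is expected, a 1.8-fold higher number from compound 1 to compound 4 (0.27 log units; within the scatter). For compound 4 the estimate is 350 nM, between 90 nM and 1500 nM.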

Compound 4, inhibition constant: 460 nM
Beside the measured number, compound 4's estimate is 1.3-fold (0.12 log units) below it; the measured number falls inside the stated range.
By their numbers in this assay, from the lowest: compound 1; then compound 4; then compound 2. At a limit, above all of these: compound 3.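

In this assay 3-cyanophenyl in place of 5-ethylfuran-2-yl gives a 2.4-fold higher number from compound 1 to compound 4 (0.38 log units; beyond the scatter). Going by these compounds alone, this is the first step at this position, between two ring nitrogen atoms, that changes one place only, and it shows that a six-membered aromatic ring of carbon only can replace the furan at a modest cost. Nothing measured here gives a cause for this step.

From the compounds shown here alone, whether the step would keep its size with a different amine on the shared core remains open. So does the effect of a carboxylic acid or a methoxy group in place of the nitrile.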